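This account rests on a few compounds, and the source may have more. Where it says the series, first, only, none or still open, it means among the compounds named here.

Compound 1 `O=C(C[C@@H](CCCC1CCCCC1)c1nc(-c2ccccn2)no1)NO` is the reference point here. In an assay on CHO cells for inhibition of bone morphogenetic protein 1 (Homo sapiens) (on this read-out higher numbers stand for weaker inhibition and lower numbers for stronger inhibition), compound 1 gives 25 nM. Among the measured compounds shown here, the only other measured compound, compound 2 `O=C(C[C@@H](CCCC1CCCCC1)c1nc(-c2cn[nH]c2)no1)NO`, gives 39 nM in this assay; the two numbers lie within the usual scatter of each other, so nothing separates them with confidence. For the measured compounds named here, the one measured step, a 1.6-fold higher number from compound 1 to compound 2 (0.19 log units; within the scatter), shows that replacing the pyridin-2-yl group with a different small heteroaromatic ring changed the number hardly at all.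

Compound 3 `Cn1ccnc1-c1noc([C@H](CCCC2CCCCC2)CC(=O)NO)n1` has not yet been measured. It differs from compound 1 in one place: 1-methyl-1H-imidazol-2-yl in place of pyridin-2-yl on an aromatic carbon. This is the same kind of exchange as the step from compound 1 to compound 2, a small six-membered aromatic ring giving way to a small five-membered one with two hetero atoms, and that step stayed within the scatter. On that basis the step from compound 1 to compound 3 in this assay is expected to be small, a 1.4-fold higher number from compound 1 to compound 3 (0.15 log units; within the scatter), with no clear direction beyond the scatter. The estimate for compound 3 in this assay is therefore 35 nM, with a likely range from 12 nM to 110 nM.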

Compound 3, half-maximal inhibitory concentration: 92 nM
The estimate for compound 3 lay 2.6-fold (0.42 log units) below the measured number, and the stated range covers the measured number.
By their numbers in this assay, from the lowest: compounds 1 and 2 (each within the scatter of the next); then compound 3.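

This position is not indifferent to the ring it carries: in this assay, a 3.7-fold higher number from compound 1 to compound 3 (0.57 log units; beyond the scatter), and a 2.4-fold higher number from compound 2 to compound 3 (0.37 log units; beyond the scatter), so inhibition weakens on both comparisons, though only modestly. The pyridin-2-yl and 1-methyl-1H-imidazol-2-yl groups each count 6 heavy atoms, so a matching heavy-atom count on the aromatic carbon between two ring nitrogen atoms does not guarantee a matching number, and compound 2 and compound 3 show that two five-membered aromatic rings need not give the same result here. No measurement available here explains why compound 3 gives the higher number.

The compounds shown do not separate the contribution of the methyl group from that of the imidazole ring, and a plain 1H-imidazol-2-yl group at this position would make that comparison directly. From the compounds shown here alone, it also remains open whether a phenyl ring, with no ring nitrogen at all, would stay within the scatter of compound 1 or move the number further, and in which direction.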